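A Four-Membered Ring Chain on a Quickly Cleared Core

This account rests on a few compounds, and the source may have more. Where it says the series, first, only, none or still open, it means among the compounds named here.

compound 1 `CN(C[C@H]1Cc2ncccc2CN1)[C@H]1CCCc2cccnc21`: 7%
compound 2 `NC(=O)NCCCCN(C[C@H]1Cc2ncccc2CN1)[C@H]1CCCc2cccnc21`: 1%
compound 3 `NC(=O)NC/C=C/CN(C[C@H]1Cc2ncccc2CN1)[C@H]1CCCc2cccnc21`: 1%

In an ADME assay on microsomes from liver (Rattus norvegicus) for metabolic stability, using NADPH, with a stated time of 10 min (on this read-out higher numbers stand for a more stable compound and lower numbers for a less stable compound), compound 1 shows the highest of the three numbers, but its gaps to compound 2 and compound 3 both lie within the usual scatter, so all three compounds are cleared quickly. Compound 4 `c1cnc2c(c1)CN[C@@H](CN(CCCCNC1COC1)[C@H]1CCCc3cccnc31)C2` differs from compound 1 in one place: a group of 8 heavy atoms (6 carbon, 1 nitrogen, 1 oxygen; one four-membered non-aromatic ring with 1 hetero atom) in place of a hydrogen atom, on a saturated chain carbon bound to an amine nitrogen. Within the data shown here, two measured steps bear on this change, since each adds a chain at the same place: a number 6 percentage points lower from compound 1 to compound 2 (within the scatter) and a number 6 percentage points lower from compound 1 to compound 3 (within the scatter), both within the scatter. The step from compound 1 to compound 4 is therefore expected to be a number 4 percentage points lower from compound 1 to compound 4 (within the scatter), no change beyond the scatter. For compound 4 the estimate in this assay is 3%, with a range of 0% to 12%.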

Compound 4, percent of the compound remaining: 27%
For compound 4 the middle estimate is 24 percentage points below the measured one; measured number above the stated range.
By their numbers in this assay, from the lowest: compounds 2, 3 and 1 (each within the scatter of the next); then compound 4.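

In this assay, a chain at this place can change the number: the step is a number 20 percentage points higher from compound 1 to compound 4 (beyond the scatter) and is beyond the scatter, unlike the steps to the chains of compound 2 and compound 3. Oxetan-3-yl in place of carbamoyl on an amine nitrogen gives a number 26 percentage points higher from compound 2 to compound 4 (beyond the scatter) and the other chain gives way with a number 26 percentage points higher from compound 3 to compound 4 (beyond the scatter) so what ends the chain counts, not just its presence. Nothing available explains this rise. From the compounds shown here alone, whether cyclobutyl, with carbon in place of the ring oxygen, would give a similar number stays open.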